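Ethyl Ester in Place of Aminophenyl: An Expected Shift

The source may hold more compounds than are shown below. What is called first, only, known or untested is meant among the compounds shown, and "the series" means these compounds.

Measured compounds in a functional assay on BXPC-3 cells (Homo sapiens) for cytotoxicity, read by MTT assay, with a stated time of 72 h; a lower number here means a stronger inhibitor, a higher number a weaker inhibitor:
- compound 1 `COC(=O)c1ccc(NC2=CC(=O)c3ncncc3C2=O)cc1` gives 5800 nM.
- compound 2 `NS(=O)(=O)c1ccc(NC2=CC(=O)c3ncncc3C2=O)cc1` is reported only as an assay limit, > 10000 nM.
- compound 3 `Nc1ccc(-c2ccc(NC3=CC(=O)c4ncncc4C3=O)cc2)cc1` gives 3500 nM.

Compound 3 holds the lowest of the two numbers in this assay, with compound 1 nearest; the step of a 1.7-fold lower number from compound 1 to compound 3 (0.22 log units; within the scatter) stays within the scatter, so no order between them is claimed. Compound 4 `CCOC(=O)c1ccc(NC2=CC(=O)c3ncncc3C2=O)cc1` is not yet measured. It differs from compound 3 thus: ethoxycarbonyl in place of 4-aminophenyl on an aromatic carbon.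

The step that bears most directly on this change is a 1.7-fold lower number from compound 1 to compound 3 (0.22 log units; within the scatter), since it exchanges the same aminophenyl group for a methyl ester and was small. The step of an at least 2.8-fold lower number from compound 2 to compound 3 (0.45 log units; beyond the scatter) concerns a sulfamoyl group and is less comparable. Reversing the ester-to-aminophenyl exchange, an ethoxycarbonyl entering in place of 4-aminophenyl is therefore expected to give a step of about a 1.6-fold higher number from compound 3 to compound 4 (0.20 log units; within the scatter), upward and still within the scatter. Compound 4 is estimated at 5500 nM, with a range from 2500 nM to 12000 nM.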

Compound 4, half-maximal inhibitory concentration: 5900 nM
Compound 4: middle estimate off by 1.1-fold (0.03 log units), on the low side; the measured number falls inside the stated range.
By their numbers in this assay, from the lowest: compounds 3, 1 and 4 (each within the scatter of the next). At a limit, above all of these: compound 2.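

In this assay, replacing 4-aminophenyl with ethoxycarbonyl gives a 1.7-fold higher number from compound 3 to compound 4 (0.23 log units; within the scatter), so at this place, para to a large group, a group with no ring cannot be told apart from one that carries an aromatic ring. Extending the ester by a single methyl gives a 1.0-fold higher number from compound 1 to compound 4 (0.01 log units; within the scatter), which shows that the methyl and ethyl esters cannot be separated here. Read against the sulfamoyl group, the result is only an at least 1.6-fold lower number from compound 2 to compound 4 (0.22 log units; that floor lies within the scatter), a floor that sets no order, and compound 2 stands as an assay limit: the limit of > 10000 nM in this assay, at which 1 of the 4 values shown sits.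

Going by these compounds, whether a carboxylic acid, an amide or a longer ester chain such as butoxycarbonyl would move the number beyond the scatter remains open. The compounds shown also leave open whether any of these groups would behave the same way in another cell line.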